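Pyridinylsulfanyl Chain in Place of the Fluorophenyl Sulfide

The source may hold more compounds than are shown below. What is called first, only, known or untested is meant among the compounds shown, and "the series" means these compounds.

Of the compounds shown here, three built on a shared core have been measured in a functional assay on PC-3 cells (Homo sapiens) for inhibition, read by MTT assay, with a stated time of 48 h; on this read-out higher numbers stand for weaker inhibition and lower numbers for stronger inhibition. Compound 1 `C=C1CC[C@@H]2[C@](C)(CO)[C@H](O)CC[C@@]2(C)[C@@H]1CC(Sc1ccccc1)C1=CCOC1=O` gives 14000 nM. Compound 2 `C=C1CC[C@@H]2[C@](C)(CO)[C@H](O)CC[C@@]2(C)[C@@H]1C/C=C1/C(=O)OCC1OC(=O)CSc1ccc(F)cc1` gives 13000 nM. Compound 3 `C=C1CC[C@@H]2[C@](C)(CO)[C@H](O)CC[C@@]2(C)[C@@H]1C/C=C1/C(=O)OC[C@H]1OC(=O)CSc1ccc(F)cc1` gives 14000 nM, level with compound 1 at the digits shown and within the scatter of compound 2. Among the measured compounds shown here, the only single-point step measured so far runs a 1.1-fold higher number from compound 2 to compound 3 (0.03 log units; within the scatter), and the two compounds differ only in the fact that one of compounds 2 and 3 is drawn with a defined configuration and the other without, at the place where they differ. Compound 3 thus stands among three numbers that cannot be told apart.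

The next compound, compound 4 `C=C1CC[C@@H]2[C@](C)(CO)[C@H](O)CC[C@@]2(C)[C@@H]1C/C=C1/C(=O)OC[C@H]1OC(=O)CCCSc1ccccn1`, differs from compound 3 by 2-((pyridin-2-yl)sulfanyl)ethyl in place of (4-fluorophenyl)sulfanyl on a saturated chain carbon bound to a carbonyl carbon. For the measured compounds named here, no measured step touches the sulfanyl-bearing side chain: the step from compound 2 to compound 3 concerns a stereocentre elsewhere, and compound 1, which carries a different arrangement of its sulfanyl group altogether, sits at the same level as the other two. With all three values within the scatter of one another and no measured change at this place, the expected step of no change at the digits printed from compound 3 to compound 4 (within the scatter) from compound 3 to compound 4 in this assay is none beyond the scatter. Compound 4 is therefore estimated at 14000 nM, with a range from 5000 nM to 40000 nM.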

Compound 4, half-maximal inhibitory concentration: 14000 nM
Beside the measured number, compound 4's estimate shows no gap at the digits printed, and the stated range covers the measured number.
By their numbers in this assay, from the lowest: compounds 2, 1, 3 and 4 (each within the scatter of the next).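

With this step the side chain has a measured change of its own: in this assay, 2-((pyridin-2-yl)sulfanyl)ethyl in place of (4-fluorophenyl)sulfanyl on a saturated chain carbon bound to a carbonyl carbon gives no change at the digits printed from compound 3 to compound 4 (within the scatter). The exchange is not a small one, since the fluorine goes, a six-membered aromatic ring with a hetero atom replaces one of carbon only, and the chain grows, cut one bond further out, from ((4-fluorophenyl)sulfanyl)methyl to 3-((pyridin-2-yl)sulfanyl)propyl, yet for this pair all of that together leaves the read-out within the scatter. The compounds shown offer no information on why the number holds at this place.

From the compounds shown here alone, since the ring and the chain length change together, it stays open whether either change alone would also leave the number within the scatter, as the two could offset each other or both could be without effect. Also open, going by these compounds, is what a clearly different group on this chain would give, such as an amine, a carboxylic acid or a much longer chain.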